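The source may report more compounds than this note shows. Statements on the series, on what has been measured and on what is new or still open speak of the compounds shown alone.

Compound 3 `C=CC(=O)Nc1cc(Nc2nc(C)cc(-c3cn(C)c4ccccc34)n2)c(OC)cc1N(C)CCN(C)C` gives 12600 nM in a functional assay on HepG2 cells (Homo sapiens) for antiproliferative activity, read by MTT assay, with a stated time of 72 h (on this read-out lower numbers stand for stronger inhibition and higher numbers for weaker inhibition), the highest of the two numbers available, while compound 1 `C=C(Cl)C(=O)Nc1cc(Nc2nccc(-c3cn(C)c4ccccc34)n2)c(OC)cc1N(C)CCN(C)C` gives 1390 nM in this assay. Compound 2 `COc1cc(N(C)CCN(C)C)c(NC(=O)C(Cl)=C(Cl)Cl)cc1Nc1nccc(-c2cn(C)c3ccccc23)n1` reaches only a limit in this assay, > 50000 nM, which is the limit of > 50000 nM in this assay, at which 1 of the 3 values shown sits. Compound 4 `C=C(Cl)C(=O)Nc1cc(Nc2nc(C)cc(-c3cn(C)c4ccccc34)n2)c(OC)cc1N(C)CCN(C)C` carries chloro in place of hydrogen on a double-bonded chain carbon bound to a carbonyl carbon. The only measured step that bears on this change is an at least 35-fold higher number from compound 1 to compound 2 (1.55 log units; beyond the scatter), where further chlorine on the chain went with a large loss; here one chlorine enters where compound 3 has none, and no direct comparison of a vinyl with a 1-chloroethenyl group exists among these compounds. The chemist therefore expects a step of a 1.8-fold lower number from compound 3 to compound 4 (0.26 log units; within the scatter) in this assay, modest and uncertain in direction. Compound 4 is expected to give about 7000 nM, between 1500 nM and 30000 nM.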

Compound 4, half-maximal inhibitory concentration: 3640 nM
The estimate for compound 4 lay 1.9-fold (0.28 log units) above the measured number; low and high end bracket the measured number.
By their numbers in this assay, from the lowest: compound 1; then compound 4; then compound 3. At a limit, above all of these: compound 2.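

In this assay, a single chlorine on the double-bonded chain carbon bound to the carbonyl carbon now has a direct comparison, and it goes with stronger inhibition, with a 3.5-fold lower number from compound 3 to compound 4 (0.54 log units; beyond the scatter). The loss seen with 1,2,2-trichloroethenyl therefore does not extend to 1-chloroethenyl, and compound 2 remains a limit rather than a number: the limit of > 50000 nM in this assay, at which 1 of the 4 values shown sits. The methyl on the aromatic carbon can now be read alone and goes with weaker inhibition, with a 2.6-fold higher number from compound 1 to compound 4 (0.42 log units; beyond the scatter).

On these data alone, whether 1-bromoethenyl or 1-fluoroethenyl would match 1-chloroethenyl remains open. So does how an amine in place of that methyl would read.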